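The source may hold more compounds than are shown below. What is called first, only, known or untested is meant among the compounds shown, and "the series" means these compounds.

Working notes on the series. Compound 1 `COc1cc2c(cc1C)NC(=O)/C2=C/c1c(Cl)n(C)c2cc(C)c(OC)cc12` and compound 2 `COc1cc2c(cc1C)N(C)C(=O)/C2=C/c1c(Cl)n(C)c2cc(C)c(OC)cc12` share one core; compound 3 `CN(C)c1ccc2[nH]c(Cl)c(/C=C3/C(=O)Nc4ccc(O)cc43)c2c1` and compound 4 `CN(C)c1ccc2[nH]c(Cl)c(/C=C3/C(=O)N(C)c4ccc(O)cc43)c2c1` share another, and the difference between the two cores is not broken down here. In a functional assay on NSCLC cells (Homo sapiens) for inhibition, with a stated time of 48 h (on this read-out higher numbers stand for weaker inhibition of growth and lower numbers for stronger inhibition of growth), compound 1 gives 34700 nM and compound 2 gives 19500 nM. The change between them, (methyl in place of hydrogen on an amide-type nitrogen in a ring), produced a 1.8-fold lower number from compound 1 to compound 2 (0.25 log units; within the scatter). In this assay compound 3 gives 5130 nM, the lowest of the three measured numbers, with its gaps to compound 2 and to compound 1 both beyond the scatter. Compound 4 carries the same change as compound 2, namely (methyl in place of hydrogen on an amide-type nitrogen in a ring), on the core of compound 3; the place is the same in both cases, so this is the same change. Among the measured compounds shown here, only one earlier instance exists, and it stayed within the scatter, so the step to compound 4 is expected to be small as well, about a 1.5-fold lower number from compound 3 to compound 4 (0.17 log units; within the scatter), resting on the step from compound 1 to compound 2 in this assay. On that basis compound 4 is expected to give about 3500 nM in this assay, with a likely range from 1500 nM to 9000 nM.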

Compound 4, concentration for 50% growth inhibition: 6610 nM
The estimate for compound 4 lay 1.9-fold (0.28 log units) below the measured number, and the stated range covers the measured number.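

In this assay methyl in place of hydrogen on an amide-type nitrogen in a ring gave a 1.3-fold higher number from compound 3 to compound 4 (0.11 log units; within the scatter) on the core of compound 3, so on this core too the step stays small. Set beside the earlier instance, the change behaves alike on the two cores within what the measurements can resolve: the same change on two cores in this assay, a 1.8-fold lower number (0.25 log units; within the scatter) from compound 1 to compound 2 and a 1.3-fold higher number (0.11 log units; within the scatter) from compound 3 to compound 4, 2.3-fold (0.36 log units) apart, within the scatter of two such steps. This supports carrying the change between these two cores without expecting a step beyond the scatter, but it does not show that the opposite directions of the two steps are real, and two cores say nothing about other cores in the series.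

The compounds shown leave open whether a larger group on that nitrogen, such as a longer chain or a chain ending in an amine or a carboxylic acid, would move the number beyond the scatter. They also leave open which of the several differences between the two cores accounts for the gap between their numbers.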